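The source may report more compounds than this note shows. Statements on the series, on what has been measured and on what is new or still open speak of the compounds shown alone.

Measured compounds:
compound 1, `Cn1c(-c2cccc(F)c2)cnc1NC(=O)c1ccc(F)cc1`; in a toxicity assay on THP-1 cells (Homo sapiens) for inhibition (a higher number here means that more compound is tolerated, a lower number that less compound is tolerated), compound 1 gives 58000 nM.
compound 2, `COc1ccc(-c2cnc(NC(=O)c3ccc(F)cc3)n2C)cc1`; in this assay compound 2 gives >= 50000 nM, which is a limit of the assay and not a number.

Compound 2 thus stands at the limit of >= 50000 nM in this assay, at which 1 of the 2 values shown sits, and its position relative to compound 1 cannot be read. Within the data shown here, the only measured step, a step that the limit leaves unreadable from compound 1 to compound 2, is unreadable, so no measured step sizes the change at hand. Compound 3, `Cc1cccc(-c2cnc(NC(=O)c3ccc(F)cc3)n2C)c1`, differs from compound 2 by 3-methylphenyl in place of 4-methoxyphenyl on an aromatic carbon. Compound 3 is expected to show no movement beyond the scatter in this assay, an expected step that the limit leaves unreadable from compound 2 to compound 3. The estimate for compound 3 is 55000 nM, expected to lie between 28000 nM and 110000 nM.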

Compound 3, half-maximal cytotoxic concentration: > 100000 nM
Compound 3 ended at the assay's limit (the forecaster's own chance of this, stated with the estimate: 60%); middle value at least 1.8-fold (0.25 log units) away from the limit.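

In this assay compound 3 gives a limit of the assay and not a number: the limit of > 100000 nM in this assay, at which 1 of the 3 values shown sits. Swapping 3-fluorophenyl for 3-methylphenyl gives the first readable step at this place on the shared core, an at least 1.7-fold higher number from compound 1 to compound 3 (0.23 log units; that floor lies within the scatter), so this floor alone does not place compound 3 beyond the scatter from compound 1. The steps that involve compound 2 cannot be read, and its value is also a limit: the limit of >= 50000 nM in this assay, at which 1 of the 3 values shown sits.

As far as these compounds go, how far compound 3 lies past its limit stays open, as does what an amine or a carboxylic acid on this phenyl ring would give.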